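Cyclohexyl in place of 3-chlorophenyl: what compound 4 may give

The compounds below may be only part of what the source reports. "The series", "measured", "known", "first", "only" and "open" are said of these compounds alone.

Three compounds share a core and were measured in a functional assay on HepG2 cells (Homo sapiens) for antiproliferative activity, read by CCK-8 assay, with a stated time of 72 h, tested at 2 uM; on this read-out lower numbers stand for a weaker effect and higher numbers for a stronger effect at the one concentration tested. Compound 1 `CCC(C)n1cnc2c(NCc3ccc(C(=O)Nc4ccccc4N)cc3)nc(Cl)nc21` gives 45% in this assay. Compound 2 `Nc1ccccc1NC(=O)c1ccc(Cn2cnc3c(Nc4ccccc4)nc(Cl)nc32)cc1` gives 49.6%. Compound 3 `Nc1ccccc1NC(=O)/C=C/c1ccc(Cn2cnc3c(Nc4cccc(Cl)c4)nc(Cl)nc32)cc1` gives 35.8%, the lowest of the three readings: compound 1 lies nearest, within the scatter of it, while compound 2 lies furthest, beyond the scatter. No two of these compounds differ in one place alone, so none of them shows a single-point step.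

Compound 4 `Nc1ccccc1NC(=O)/C=C/c1ccc(Cn2cnc3c(NC4CCCCC4)nc(Cl)nc32)cc1` differs from compound 3 in one place: cyclohexyl in place of 3-chlorophenyl on a nitrogen on an aromatic ring. For the measured compounds named here, nothing among the measured compounds shows what this kind of change does in this assay. The expectation is therefore a step from compound 3 to compound 4 that does not clearly leave the scatter, with a wide range. The estimate for compound 4 is 35%, between 15% and 55%, which means an expected step of a number 0.8 percentage points lower from compound 3 to compound 4 (within the scatter).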

Compound 4, a percentage reported as inhibition, at one concentration (the size of the read-out at that concentration, not a potency): 3.83%
Beside the measured number, compound 4's estimate is 31.2 percentage points above it, and the stated range ends above it.
By their numbers in this assay, from the lowest: compound 4; then compounds 3, 1 and 2 (each within the scatter of the next, the first and the last beyond it).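

In this assay, for the compounds shown here, cyclohexyl in place of 3-chlorophenyl on a nitrogen on an aromatic ring gives a number 32 percentage points lower from compound 3 to compound 4 (beyond the scatter), the first step in this set that changes one place alone. It shows that, with the rest of compound 3 unchanged, the reading at the one concentration tested depends strongly on the group at this position, and that this exchange is not neutral. Nothing at hand accounts for the size of this step.

The change removes the chlorine and the aromatic ring together, so the compounds shown do not tell which of the two carries the step. Going by these compounds, what a plain phenyl, a benzyl or a straight butyl chain would give at this position, with the rest of compound 3 kept, remains open.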